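From methoxyphenyl to dichlorophenyl: compound 3 to compound 4

A few compounds are considered here, and "the series" means these few. Any claim that something is new, unique, unknown or untested is made for them only; others in the source may bear on it.

Compound 1 `COc1cccc(/C=C2\CCC/C(=C\c3ccccc3Br)C2=O)c1OC`: > 50000 nM (a limit)
Compound 2 `COc1cccc(/C=C2\CCC/C(=C\c3cccc(OC)c3OC)C2=O)c1`: 16400 nM
Compound 3 `COc1ccc(/C=C2\CCC/C(=C\c3cccc(OC)c3OC)C2=O)cc1`: 43500 nM

These results come from an ADME assay on NHDF cells (Homo sapiens) for cytotoxicity, read by MTT assay, with a stated time of 72 h; on this read-out lower numbers stand for stronger inhibition and higher numbers for weaker inhibition. For compound 1 the result is a limit and not an exact number, > 50000 nM. Of the two exact numbers, compound 3 has the higher, 43500 nM. The gap between them is a 2.7-fold higher number from compound 2 to compound 3 (0.42 log units; beyond the scatter).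

The next compound is compound 4 `COc1cccc(/C=C2\CCC/C(=C\c3ccc(Cl)cc3Cl)C2=O)c1OC`, and the change is 2,4-dichlorophenyl in place of 4-methoxyphenyl on a double-bonded chain carbon bound to a double-bonded ring carbon. A 2,4-dichlorophenyl thus replaces the 4-methoxyphenyl.

The closest guide is the opposite kind of swap, a 4-methoxyphenyl replacing a 2-bromophenyl, which gave an at least 1.1-fold lower number from compound 1 to compound 3 (0.06 log units; that floor lies within the scatter). That step gives only a floor, and the floor lies within the scatter. Replacing the same 2-bromophenyl with a 3-methoxyphenyl gave an at least 3.0-fold lower number from compound 1 to compound 2 (0.48 log units; beyond the scatter), but compound 4 does not carry that group. Neither step points to a large change, so the number should stay high in this assay.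

The expected step is a 1.2-fold lower number from compound 3 to compound 4 (0.09 log units; within the scatter), which is estimated to stay within the scatter. The estimate for compound 4 is 35000 nM, with an expected range from 12000 nM to 70000 nM.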

Compound 4, half-maximal inhibitory concentration: 49200 nM
Beside the measured number, compound 4's estimate is 1.4-fold (0.15 log units) below it, and the stated range covers the measured number.
By their numbers in this assay, from the lowest: compound 2; then compounds 3 and 4 (each within the scatter of the next). At a limit, above all of these: compound 1.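

In this assay, a 2,4-dichlorophenyl and a 4-methoxyphenyl on a double-bonded chain carbon bound to a double-bonded ring carbon cannot be told apart: a 1.1-fold higher number from compound 3 to compound 4 (0.05 log units; within the scatter). Here a group with one hydrogen-bond acceptor gives way to one with none and with two chlorines, yet the number stays within the scatter, whereas the same 2,4-dichlorophenyl set against a 3-methoxyphenyl gives a 3.0-fold higher number from compound 2 to compound 4 (0.48 log units; beyond the scatter), which leaves compound 2 with the lowest exact number of the set. The comparison with compound 1 yields only a floor, an at least 1.0-fold lower number from compound 1 to compound 4 (0.00 log units; that floor lies within the scatter), and the result for compound 1 is a limit: the limit of > 50000 nM in this assay, at which 1 of the 4 values shown sits.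

Going by these compounds, these compounds carry only halogen-bearing or methoxy-bearing phenyl groups at this position, so it stays open whether an amine or a carboxylic acid on that ring would bring the number down. On these data alone, it also stays open whether a 3-chlorophenyl would match compound 2, which would show whether the lower number follows that ring position or the methoxy group itself.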